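The compounds below may be only part of what the source reports. "The series", "measured", "known", "first", "only" and "open" are said of these compounds alone.

In an ADME assay on HCT-116 cells (Homo sapiens) for cytotoxicity, read by CellTiter-Glo, with a stated time of 72 h (on this read-out higher numbers stand for weaker inhibition and lower numbers for stronger inhibition), compound 1 (`Cc1ccc(-c2ccccc2S(=O)(=O)N2CCC(N3CCC(C)CC3)CC2)cc1`) gives > 5000 nM as a limit of the assay, not a number. Compound 2 (`Cc1ccc(C2CCN(S(=O)(=O)c3c(C)cc(C)cc3C)CC2)cc1`) likewise gives only a limit, > 5000 nM in the same read-out. For the measured compounds named here, only the limit of > 5000 nM in this assay, at which 2 of the 2 values shown sit, stands on record, so no measured step is available to guide the next comparison. Compound 3 (`COc1ccc(-c2ccccc2S(=O)(=O)N2CCC(N3CCC(C)CC3)CC2)cc1`) changes compound 1 in one place, from 4-methylphenyl to 4-methoxyphenyl, with methoxy in place of methyl on an aromatic carbon. No shift beyond the scatter is expected in this assay and no direction is favoured, since compound 1 offers only its limit of > 5000 nM as a starting point. The estimated step that the limit leaves unreadable from compound 1 to compound 3 is accordingly expected to be small. For compound 3 the expected value is 6000 nM (estimated range 2500 nM to 15000 nM), most likely reported again as a limit.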

Compound 3, half-maximal inhibitory concentration: > 5000 nM
Compound 3: a limit, no number (the forecaster's own chance of this, stated with the estimate: 85%); the middle value is on the limit's open side.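

No step can be read from compound 1 to compound 3 in this assay, because both values are limits of the assay and not numbers: the limit of > 5000 nM in this assay, at which 3 of the 3 values shown sit.

The compounds shown leave open whether any change to the core of compound 1 gives a measurable value in this assay at all.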